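This account rests on a few compounds, and the source may have more. Where it says the series, first, only, none or still open, it means among the compounds named here.

Measured compounds in a functional assay on NCI-H460 cells (Homo sapiens) for inhibition, read by MTT assay, with a stated time of 72 h; on this read-out higher numbers stand for weaker inhibition and lower numbers for stronger inhibition:
- compound 1 `COc1cc2c(Oc3ccc(NC(=O)c4nn(-c5ccccc5C(F)(F)F)c(=O)cc4C)cc3F)ccnc2cc1OCCCN1CCCC1`: 210 nM
- compound 2 `COc1cc2c(Oc3ccc(NC(=O)c4nn(-c5ccccc5C(F)(F)F)c(=O)cc4C)cc3F)ccnc2cc1OCCCN1CCC(C)CC1`: 200 nM
- compound 3 `COc1cc2c(Oc3ccc(NC(=O)c4nn(-c5ccccc5C(F)(F)F)c(=O)cc4C)cc3F)ccnc2cc1OCCCN1CCN(C)CC1`: 240 nM

Compound 1 gives the second highest of the three numbers, but all three sit together: a 1.1-fold lower number from compound 1 to compound 2 (0.02 log units; within the scatter) and a 1.1-fold higher number from compound 1 to compound 3 (0.06 log units; within the scatter) are both within the scatter, as is a 1.2-fold higher number from compound 2 to compound 3 (0.08 log units; within the scatter). The three measured steps differ only in the amine at the end of the three-carbon chain, and none of them reads as a change in potency.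

Compound 4 `COc1ccc(-n2nc(C(=O)Nc3ccc(Oc4ccnc5cc(OCCCN6CCCC6)c(OC)cc45)c(F)c3)c(C)cc2=O)cc1` changes a different part of the molecule: 4-methoxyphenyl in place of 2-(trifluoromethyl)phenyl on an aromatic nitrogen. Going by the values given here, no measured step touches this aryl group, so there is nothing that bears directly on the change; the steps on the amine end say only that the shared core tolerates small variation there without moving the number. The expectation for compound 4 therefore rests on the value of compound 1 alone, with a wide range and a slight lean toward a weaker result. Compound 4 is estimated at 350 nM in this assay, within 100 nM to 1500 nM, which means an expected step of a 1.7-fold higher number from compound 1 to compound 4 (0.22 log units; within the scatter).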

Compound 4, half-maximal inhibitory concentration: 3610 nM
Estimate against measurement, compound 4: 10-fold (1.01 log units) below; measured number outside the range, above it.
By their numbers in this assay, from the lowest: compounds 2, 1 and 3 (each within the scatter of the next); then compound 4.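

In this assay the aryl group on the aromatic nitrogen is a position that moves the number, with 4-methoxyphenyl in place of 2-(trifluoromethyl)phenyl giving a large step (a 17-fold higher number from compound 1 to compound 4 (1.24 log units; beyond the scatter)). The amine steps among compound 1, compound 2 and compound 3 all stayed within the scatter, so the series is sensitive at this aryl group in a way the amine end did not show. Nothing available here accounts for the size of this step.

The single change replaces one group with another at a different place on the phenyl ring, so the compounds shown leave open whether the group or its placement matters. 2-Methoxyphenyl and 4-(trifluoromethyl)phenyl on the same nitrogen would separate the two, and unsubstituted phenyl would give a reference for both.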